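The compounds below may be only part of what the source reports. "The series", "measured", "known", "first", "only" and "open" are said of these compounds alone.

In an assay for inhibition of inositol hexakisphosphate kinase 2 (Homo sapiens), read by colorimetric assay, coupled enzyme assay and malachite green, with a stated time of 120 min, in the presence of a further agent that is not named here (a higher number here means a weaker inhibitor, a lower number a stronger inhibitor), the three measured compounds stand as follows:

Compound 1 `O=C(O)c1ccc2noc(-c3ccc(Cc4ccccc4)cc3)c2c1`: 65 nM
Compound 2 `O=C(O)c1ccc2noc(-c3ccc(Oc4ncc(Cl)cc4Cl)cc3)c2c1`: 650 nM
Compound 3 `O=C(O)c1ccc2noc(-c3ccc(N4CCCC4=O)cc3)c2c1`: 480 nM

Compound 3 gives the second highest number of the three. The step of a 1.4-fold lower number from compound 2 to compound 3 (0.13 log units; within the scatter) lies within the scatter, while the step of a 7.4-fold higher number from compound 1 to compound 3 (0.87 log units; beyond the scatter) lies beyond it. Compound 4 `O=C(O)c1ccc2noc(-c3ccc(NC(=O)C4CCCC4)cc3)c2c1` has not yet been measured; it differs from compound 3 by (cyclopentylcarbonyl)amino in place of 2-oxopyrrolidin-1-yl on an aromatic carbon. Among the measured compounds shown here, the two measured exchanges at this position, a 10-fold higher number from compound 1 to compound 2 (1.00 log units; beyond the scatter) and a 7.4-fold higher number from compound 1 to compound 3 (0.87 log units; beyond the scatter), both moved the number modestly, and no measured pair swaps a ring-bound lactam for an open amide. The expected step for compound 4 is therefore small, a 1.6-fold lower number from compound 3 to compound 4 (0.20 log units; within the scatter), with either direction possible. Compound 4 is estimated at 300 nM, in a range from 90 nM to 1000 nM.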

Compound 4, half-maximal inhibitory concentration: 190 nM
For compound 4 the middle estimate is 1.6-fold (0.20 log units) above the measured one; the measured number falls inside the stated range.
By their numbers in this assay, from the lowest: compound 1; then compound 4; then compounds 3 and 2 (each within the scatter of the next).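

Replacing the ring-bound lactam with an open amide that carries a cyclopentyl ring and an amide hydrogen gives a 2.5-fold lower number from compound 3 to compound 4 (0.40 log units; beyond the scatter), so this position responds to the form of the amide. The same group gives a 3.4-fold lower number from compound 2 to compound 4 (0.53 log units; beyond the scatter), yet benzyl remains ahead with a 2.9-fold higher number from compound 1 to compound 4 (0.47 log units; beyond the scatter), placing compound 4 between these groups. No measured evidence here explains these steps.

The shown compounds leave the amide hydrogen and the added carbon atoms unseparated. An N-methyl amide or a smaller acetyl amide could help to tell their contributions apart.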